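Swapping cyclopentyloxy for phenyl on the triple bond

The source may hold more compounds than are shown below. What is called first, only, known or untested is meant among the compounds shown, and "the series" means these compounds.

- compound 1 `Cc1ccc(C#Cc2c([N+](=O)[O-])nc3n2CC(C)O3)cc1` with 4440 nM
- compound 2 `CC1Cn2c(nc([N+](=O)[O-])c2C#COC2CCCC2)O1` with 8350 nM

In an ADME assay on HepG2 cells (Homo sapiens) for cytotoxicity, read by MTT assay, with a stated time of 24 h (on this read-out higher numbers stand for lower toxicity in this test and lower numbers for higher toxicity in this test), compound 2 gives 8350 nM and has a single neighbour for comparison. The gap is a 1.9-fold higher number from compound 1 to compound 2 (0.27 log units; within the scatter) and so the two stand level.

Compound 3 `CC1Cn2c(nc([N+](=O)[O-])c2C#Cc2ccccc2)O1` has not been measured yet and differs from compound 2 in one place: phenyl in place of cyclopentyloxy on a triple-bonded carbon.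

Among the measured compounds shown here, only one measured step bears on this change. It put cyclopentyloxy in place of 4-methylphenyl on the same triple-bonded carbon, and its size is a 1.9-fold higher number from compound 1 to compound 2 (0.27 log units; within the scatter) which stays within the scatter. Compound 3 replaces cyclopentyloxy with phenyl, which differs from 4-methylphenyl only by the methyl. One small step is thin evidence, but it points to a slightly lower number at most, and no step beyond the scatter is expected in this assay here. The estimated step is a 1.6-fold lower number from compound 2 to compound 3 (0.21 log units; within the scatter) (an expectation, not a measurement). For compound 3 the expected value is 5200 nM (estimated range 2300 nM to 11500 nM).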

Compound 3, half-maximal cytotoxic concentration: 5400 nM
Estimate against measurement, compound 3: 1.0-fold (0.02 log units) below; the measured number falls inside the stated range.
By their numbers in this assay, from the lowest: compounds 1, 3 and 2 (each within the scatter of the next).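

In this assay, phenyl in place of cyclopentyloxy on the triple-bonded carbon gives a small step (a 1.5-fold lower number from compound 2 to compound 3 (0.19 log units; within the scatter)), and hydrogen in place of methyl on an aromatic carbon gives another (a 1.2-fold higher number from compound 1 to compound 3 (0.09 log units; within the scatter)). The second step is new in kind, since it isolates the methyl of the 4-methylphenyl group, and it stays within the scatter just as the swap of the whole group does. Across cyclopentyloxy, phenyl and 4-methylphenyl, then, this position shows no step beyond the scatter, although a non-aromatic ring reached through oxygen and an aromatic ring of carbon only differ clearly in structure, and no measured evidence bears on why the numbers stay level.

On these data alone, all three groups on the triple-bonded carbon carry a ring, so what an amine, a carboxylic acid or a longer open carbon chain would do at this position stays open. Also open, as far as these compounds go, is whether the same level would hold with a substituent other than methyl on the aromatic ring, such as a methoxy group or a fluorine atom.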